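This account rests on a few compounds, and the source may have more. Where it says the series, first, only, none or still open, it means among the compounds named here.

Measured so far:
compound 1, `NCCCCCCOc1ccc2c(=O)c(-c3ccc(O)cc3)coc2c1`, 100 nM
compound 2, `O=C(O)CCCCCCCCCCCOc1ccc2c(=O)c(-c3ccc(O)cc3)coc2c1`, 130 nM
compound 3, `O=c1c(-c2ccc(O)cc2)coc2cc(OCCCCCCCCCO)ccc12`, 700 nM

All three share the same core and differ only in the tail that hangs from an oxygen on an aromatic ring. In an assay (Cricetulus griseus) for inhibition of aldehyde dehydrogenase, mitochondrial (Homo sapiens) (a lower number here means a stronger inhibitor, a higher number a weaker inhibitor), compound 3 gives the highest number of the three, a weaker inhibitor than compound 1 by a 7.0-fold higher number from compound 1 to compound 3 (0.85 log units; beyond the scatter) and than compound 2 by a 5.4-fold higher number from compound 2 to compound 3 (0.73 log units; beyond the scatter).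

Compound 4, `O=c1c(-c2ccc(O)cc2)coc2cc(OCCCCCCCCCCCCO)ccc12`, is not yet measured. It differs from compound 3 by 3-hydroxypropyl in place of hydroxy on a saturated chain carbon, nine bonds along the chain from an oxygen on an aromatic ring, so the tail simply grows longer while still ending in a hydroxy group.

The step that bears most directly on this is the one in which the tail of compound 2 was cut back to the shorter hydroxy-ended tail of compound 3, a 5.4-fold higher number from compound 2 to compound 3 (0.73 log units; beyond the scatter): there a longer tail went with a lower number. Lengthening the hydroxy-ended tail again in compound 4 is therefore expected to lower the number somewhat, by about a 2.3-fold lower number from compound 3 to compound 4 (0.37 log units; beyond the scatter), though the end group differs from that of compound 2 and no hydroxy-ended tail of this length has been measured.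

Compound 4 is estimated at 300 nM, with a likely range from 100 nM to 900 nM.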

Compound 4, half-maximal inhibitory concentration: 1700 nM
The estimate for compound 4 lay 5.7-fold (0.75 log units) below the measured number; the whole stated range lies below it.
By their numbers in this assay, from the lowest: compounds 1 and 2 (each within the scatter of the next); then compound 3; then compound 4.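

Growing the hydroxy-ended tail gives a weaker inhibitor in this assay (a 2.4-fold higher number from compound 3 to compound 4 (0.39 log units; beyond the scatter)), so a longer tail does not by itself go with a lower number at this position. The gap is wider against the carboxy-ended tail of compound 2 (a 13-fold higher number from compound 2 to compound 4 (1.12 log units; beyond the scatter)) and against the shorter amino-ended tail of compound 1 (a 17-fold higher number from compound 1 to compound 4 (1.23 log units; beyond the scatter)). The end group therefore appears to count alongside chain length, with both hydroxy-ended tails giving higher numbers than the amino-ended and carboxy-ended tails.

Still open, on these data alone, is whether an amine or a carboxylic acid at the end of a tail as long as that of compound 4 would restore a low number, which would help separate the end group from length. Nothing available here explains why the longer hydroxy-ended tail gives a weaker inhibitor.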